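A few compounds are considered here, and "the series" means these few. Any claim that something is new, unique, unknown or untested is made for them only; others in the source may bear on it.

In a functional assay on HeLa cells (Homo sapiens) for antiproliferative activity, read by MTT assay, with a stated time of 72 h (on this read-out higher numbers stand for weaker inhibition and lower numbers for stronger inhibition), compound 1 (`CCCNC(=O)c1cc(Oc2ccc(NC(=O)c3nn(-c4ccc(C)cc4)c(=O)cc3C)cc2F)ccn1`) gives 14200 nM and compound 2 (`CCNC(=O)c1cc(Oc2ccc(NC(=O)c3nn(-c4ccccc4C)c(=O)cc3C)cc2)ccn1`) gives 27300 nM while compound 3 (`CCCNC(=O)c1cc(Oc2ccc(NC(=O)c3nn(-c4ccc(Br)cc4F)c(=O)cc3C)cc2F)ccn1`) gives 53500 nM and so stands within the scatter of compound 2 but beyond the scatter from compound 1, with the higher number of that pair. Compound 4 (`CCCNC(=O)c1cc(Oc2ccc(NC(=O)c3nn(-c4ccccc4C)c(=O)cc3C)cc2F)ccn1`) carries 2-methylphenyl in place of 4-bromo-2-fluorophenyl on an aromatic nitrogen and is otherwise the same as compound 3.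

Among the measured compounds shown here, the one measured step at this place is a 3.8-fold higher number from compound 1 to compound 3 (0.58 log units; beyond the scatter) for 4-bromo-2-fluorophenyl in place of 4-methylphenyl, and it is modest. Read in reverse, it points to a lower number once the 4-bromo-2-fluorophenyl leaves, although 2-methylphenyl is not the same group as 4-methylphenyl. Compound 2 does carry 2-methylphenyl and gives 27300 nM but it also differs from compound 4 in its ethyl chain and in lacking a fluorine, so it is only indirect evidence. A small move toward a lower number in this assay is therefore expected, not clearly beyond the scatter. The expected change is a 1.9-fold lower number from compound 3 to compound 4 (0.28 log units; within the scatter) on this estimate. Compound 4 is estimated at 28000 nM with an expected range from 11000 nM to 65000 nM for its measurement.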

Compound 4, half-maximal inhibitory concentration: 24600 nM
The estimate for compound 4 lay 1.1-fold (0.06 log units) above the measured number, and the stated range covers the measured number.
By their numbers in this assay, from the lowest: compounds 1, 4, 2 and 3 (each within the scatter of the next, the first and the last beyond it).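

Among the compounds shown here, compound 3 now has a higher number than both compounds that differ from it only at the aromatic nitrogen: a 2.2-fold lower number from compound 3 to compound 4 (0.34 log units; beyond the scatter) in this assay adds a second replacement of 4-bromo-2-fluorophenyl to the one step available before, and it points the same way. The 2-methylphenyl and 4-methylphenyl groups are not told apart in this assay, since a 1.7-fold higher number from compound 1 to compound 4 (0.24 log units; within the scatter) is the only reading for that pair, so among these three groups the clear separation lies between 4-bromo-2-fluorophenyl and the two methylphenyl groups, not between the two placements of the methyl group. No supporting measurement is at hand to explain why 4-bromo-2-fluorophenyl differs from the methylphenyl groups.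

The compounds shown cannot say whether the higher number of compound 3 follows the bromine, the fluorine or the two together, which a 4-bromophenyl or a 2-fluorophenyl group at the same nitrogen would separate. They also leave open how an unsubstituted phenyl, a pyridyl ring, or a phenyl carrying an amine or a carboxylic acid would read at this position on the core of compound 4.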